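A Phenyl-for-Butyl Swap Repeated on Compound 3

The source may hold more compounds than are shown below. What is called first, only, known or untested is meant among the compounds shown, and "the series" means these compounds.

Three compounds sharing one core were tested in a functional assay on SMMC-7721 cells (Homo sapiens) for cytotoxicity, read by MTT assay, with a stated time of 72 h; a higher number here means a weaker inhibitor, a lower number a stronger inhibitor. Compound 1 `[O-][n+]1nc(NCOCc2ccccc2)[n+]([O-])c2ccccc21` gives 20100 nM, compound 2 `CCCCCOCNc1n[n+]([O-])c2ccccc2[n+]1[O-]` gives 17000 nM, and compound 3 `CCCCCOCNc1n[n+]([O-])c2cc(OC)ccc2[n+]1[O-]` gives 12900 nM. Compound 1 differs from compound 2 by phenyl in place of butyl on a saturated chain carbon bound to an oxygen on a saturated carbon, and this gave a 1.2-fold higher number from compound 2 to compound 1 (0.07 log units; within the scatter). Compound 3 differs from compound 2 by methoxy in place of hydrogen on an aromatic carbon, and this gave a 1.3-fold lower number from compound 2 to compound 3 (0.12 log units; within the scatter). Compound 4 `COc1ccc2c(c1)[n+]([O-])nc(NCOCc1ccccc1)[n+]2[O-]` has not yet been measured; it differs from compound 3 by phenyl in place of butyl on a saturated chain carbon bound to an oxygen on a saturated carbon, the same change seen from compound 2 to compound 1, now made on the core of compound 3. The earlier step being within the scatter, compound 4 is expected to show a similarly small step of a 1.2-fold higher number from compound 3 to compound 4 (0.07 log units; within the scatter) in this assay. Compound 4 is therefore estimated at 15000 nM, with a likely range from 7500 nM to 30000 nM.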

Compound 4, half-maximal inhibitory concentration: 21400 nM
Estimate against measurement, compound 4: 1.4-fold (0.15 log units) below; low and high end bracket the measured number.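

In this assay, putting phenyl in place of butyl on the core of compound 3 gives a 1.7-fold higher number from compound 3 to compound 4 (0.22 log units; within the scatter), and this step does not differ from the earlier one: the same change on two cores in this assay, a 1.2-fold higher number (0.07 log units; within the scatter) from compound 2 to compound 1 and a 1.7-fold higher number (0.22 log units; within the scatter) from compound 3 to compound 4, 1.4-fold (0.15 log units) apart, within the scatter of two such steps

Methoxy in place of hydrogen on an aromatic carbon gives a 1.1-fold higher number from compound 1 to compound 4 (0.03 log units; within the scatter), which likewise does not differ from its earlier counterpart: the same change on two cores in this assay, a 1.3-fold lower number (0.12 log units; within the scatter) from compound 2 to compound 3 and a 1.1-fold higher number (0.03 log units; within the scatter) from compound 1 to compound 4, 1.4-fold (0.15 log units) apart, within the scatter of two such steps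

This shows that neither change moved the number beyond the scatter on either core; it does not show that a real effect carries from one core to another, for steps this small give no effect to follow.

The compounds shown leave open whether an amine, a carboxylic acid or a chain longer than pentyl in that place would give a step beyond the scatter. They also leave open whether a nitrile in place of methoxy would do so.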